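Working notes on the step from compound 2 to compound 4

The source may report more compounds than this note shows. Statements on the series, on what has been measured and on what is new or still open speak of the compounds shown alone.

The series is read in a functional assay on DU-145 cells (Homo sapiens) for inhibition, read by trypan blue exclusion, with a stated time of 96 h; on this read-out lower numbers stand for stronger inhibition of growth and higher numbers for weaker inhibition of growth. Compound 2 `Cc1ccc(S/C(=C/c2c[nH]c3ccccc23)C(=O)c2ccc(Br)cc2)cc1` gives 10000 nM. Going by the values given here, compound 3 `Cc1ccc(S/C(=C/c2c[nH]c3ccccc23)C(=O)c2ccc(Cl)cc2)cc1` gives 10000 nM, and the step of no change at the digits printed from compound 2 to compound 3 (within the scatter) is the only single-change step among the measured pairs. Compound 1 `O=C(/C(=C\c1ccc(O)c([N+](=O)[O-])c1)S(=O)(=O)Cc1ccc(Br)cc1)c1c(F)c(F)c(F)c(F)c1F` gives 50000 nM. Compound 2 thus stands level with compound 3 at the digits shown, the two together the lowest numbers of the three, while compound 1 sits clearly higher, beyond the scatter.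

Compound 4 `Cc1ccc(S/C(=C/c2c(O)cc(O)cc2O)C(=O)c2ccc(Br)cc2)cc1` differs from compound 2 by 2,4,6-trihydroxyphenyl in place of 1H-indol-3-yl on a double-bonded chain carbon bound to a double-bonded chain carbon. Among the compounds with values here, no measured step bears directly on this change: the one step in hand alters a halogen on an aromatic carbon and leaves the group on the double-bonded chain carbon untouched. Compound 1 differs from compound 2 in more than one place, so its value cannot be tied to a single change. The expectation therefore rests on compound 2 alone and carries a wide range. For compound 4 the estimate is 10000 nM, spanning 2500 nM to 40000 nM. The expected step of no change at the digits printed from compound 2 to compound 4 (within the scatter) is accordingly none beyond the scatter, with the range widened to allow movement in either direction.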

Compound 4, concentration for 50% growth inhibition: > 100000 nM
Compound 4 gave a limit, no number (the forecaster's own chance of this, stated with the estimate: 20%); middle value at least 10-fold (1.00 log units) from the limit.
By their numbers in this assay, from the lowest: compounds 2 and 3 (each within the scatter of the next); then compound 1. At a limit, above all of these: compound 4.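

In this assay compound 4 gives > 100000 nM, which is a limit of the assay and not a number. Going by these compounds alone, replacing 1H-indol-3-yl with 2,4,6-trihydroxyphenyl on a double-bonded chain carbon bound to a double-bonded chain carbon gives an at least 10-fold higher number from compound 2 to compound 4 (1.00 log units; beyond the scatter), so the read-out responds to the group at this position, whereas the only earlier single-change step, no change at the digits printed from compound 2 to compound 3 (within the scatter), concerned a halogen on an aromatic carbon and showed no movement beyond the scatter. The size of the new step is bounded on one side only: the limit of > 100000 nM in this assay, at which 1 of the 4 values shown sits.

A single replacement cannot separate the departure of the 1H-indol-3-yl group from the arrival of the three hydroxyl groups, and a plain phenyl or a phenyl carrying one methoxy group at this place would help to tell those two contributions apart. From the compounds shown here alone, it also remains open whether any group at this position can improve on compound 2 at 10000 nM, and whether the same exchange has a similar effect in the chloro partner, compound 3.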